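The compounds below may be only part of what the source reports. "The series", "measured", "known", "first", "only" and "open" are said of these compounds alone.

Compound 2 `Cc1nn(-c2ncnc3nc[nH]c23)c2c1C(OCc1ccccc1F)CC(=O)N2` gives 4 nM in a functional assay on HEK293 cells for agonist activity at G-protein coupled receptor 39 (Homo sapiens), read by scintillation proximity assay and inositol phosphate accumulation, with a stated time of 75 min, in the presence of a further agent that is not named here (a lower number here means that less compound is needed, a higher number that more compound is needed for the effect), the lowest of the three numbers here; compound 3 `Cc1nn(-c2ncnc3nc[nH]c23)c2c1C(C(=O)N(C)c1nccs1)CC(=O)N2` gives 18 nM, and compound 1 `C/C(=N\NC(=O)c1cc2ccccc2cc1O)c1ccc(N)cc1`, built on a different framework, gives 1100 nM. Among the measured compounds shown here, the only measured change at the same position is a 4.5-fold higher number from compound 2 to compound 3 (0.65 log units; beyond the scatter), a modest step. Compound 4 `COc1ccc(CCOC2CC(=O)Nc3c2c(C)nn3-c2ncnc3nc[nH]c23)cc1` differs from compound 2 by 4-methoxybenzyl in place of 2-fluorophenyl on a saturated chain carbon bound to an oxygen on a saturated carbon. Unlike the step to compound 3, this keeps the oxygen on a saturated carbon and, cut one bond further out, reads as 2-fluorobenzyl to 2-(4-methoxyphenyl)ethyl, so a smaller shift in the same direction seems likely. Compound 4 is therefore expected to give 10 nM, within 3 nM to 40 nM. That would be an estimated step of a 2.5-fold higher number from compound 2 to compound 4 (0.40 log units; beyond the scatter), a little beyond the scatter.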

Compound 4, half-maximal effective concentration: 2 nM
Estimate against measurement, compound 4: 5.0-fold (0.70 log units) above; measured number below the stated range.
By their numbers in this assay, from the lowest: compounds 4 and 2 (each within the scatter of the next); then compound 3; then compound 1.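

The change from 2-fluorophenyl to 4-methoxybenzyl, on a saturated chain carbon bound to an oxygen on a saturated carbon, gives a 2.0-fold lower number from compound 2 to compound 4 (0.30 log units; within the scatter). With the oxygen kept, the larger 2-(4-methoxyphenyl)ethyl group therefore reads the same as 2-fluorobenzyl, unlike the step beyond the scatter to compound 3. No evidence is available that explains this result.

On these data alone, the fluorine, the methoxy group and the chain length all differ at once here, so their separate contributions stay open. As far as these compounds go, whether an amine or a carboxylic acid on the aromatic ring would be accepted also remains open.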